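This account rests on a few compounds, and the source may have more. Where it says the series, first, only, none or still open, it means among the compounds named here.

Measured in a functional assay on HT-1080 cells (Homo sapiens) for antiproliferative activity, read by MTT assay, with a stated time of 72 h; on this read-out higher numbers stand for weaker inhibition and lower numbers for stronger inhibition:
compound 1 `COc1ccc(-c2c(-c3cc(OC)c(OC)c(OC)c3)ssc2=S)cc1[N+](=O)[O-]`, 3550 nM
compound 2 `COc1ccc(-c2c(-c3cc(OC)c(OC)c(OC)c3)ssc2=S)cc1N`, 3000 nM
compound 3 `CO/N=c1/ssc(-c2cc(OC)c(OC)c(OC)c2)c1-c1ccc(OC)c([N+](=O)[O-])c1`, recorded only as a limit of > 100000 nM

Compound 4 `CO/N=c1/ssc(-c2cc(OC)c(OC)c(OC)c2)c1-c1ccc(OC)c(N)c1` has not been measured. Between compound 1 and compound 2 the change is amino in place of nitro on an aromatic carbon, and it produced a 1.2-fold lower number from compound 1 to compound 2 (0.07 log units; within the scatter). From compound 3 to compound 4 the change is amino in place of nitro on an aromatic carbon, the same change made on the other core. The difference between the core of compound 1 and the core of compound 3 is not broken down here. Compound 3 sits at the limit of > 100000 nM in this assay, at which 1 of the 3 values shown sits. Because the same change gave a 1.2-fold lower number from compound 1 to compound 2 (0.07 log units; within the scatter), the step expected for compound 4 is a step that the limit leaves unreadable from compound 3 to compound 4. The estimate for compound 4 in this assay is 150000 nM, between 40000 nM and 500000 nM, and a limit rather than a number is the more likely report.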

Compound 4, half-maximal inhibitory concentration: 915 nM
Compound 4: the middle estimate sits 160-fold (2.21 log units) above what was measured; the whole stated range lies above it.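

In this assay, amino in place of nitro on an aromatic carbon gives an at least 100-fold lower number from compound 3 to compound 4 (2.03 log units; beyond the scatter), and the size of this step does not carry over between the core of compound 1 and the core of compound 3: the same change on two cores in this assay, a 1.2-fold lower number (0.07 log units; within the scatter) from compound 1 to compound 2 and an at least 100-fold lower number (2.03 log units; beyond the scatter) from compound 3 to compound 4, at least 92-fold (1.96 log units) apart, beyond the scatter of two such steps.
Compound 3 is recorded only as a limit of > 100000 nM and the full size of the step therefore stays unread.
The comparison rests on one pair of steps: it shows that the outcome of this change depends on the core here, but gives no reason for the gap and no rule for other cores.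

The compounds shown leave open whether a hydroxyl or an acetamide in place of the nitro would separate the two cores in the same way.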